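Replacing an anilino group with a fluorophenyl on a diene core

This account rests on a few compounds, and the source may have more. Where it says the series, first, only, none or still open, it means among the compounds named here.

Compound 1 `C=C[C@@](C)(/C=C/c1ccc(Nc2ccccc2)cc1)CCC=C(C)C` carries a phenylamino group on the shared core. In a functional assay on NALM-6 cells (Homo sapiens) for cytotoxicity, with a stated time of 72 h (a lower number here means that less compound is needed, a higher number that more compound is needed for the effect), compound 1 gives only a limit of the assay, > 43400 nM. Compound 2 `C=C[C@@](C)(/C=C/c1ccc(Nc2ccc(F)c(F)c2)cc1)CCC=C(C)C` differs from compound 1 in having 3,4-difluorophenyl in place of phenyl on a nitrogen on an aromatic ring. In this assay compound 2 likewise gives only a limit of the assay, > 43400 nM. The step that the two limits leave unreadable from compound 1 to compound 2 therefore cannot be sized; the evidence is the limit of > 43400 nM in this assay, at which 2 of the 2 values shown sit, so compound 2 stands at the same limit as compound 1, with no readable step between them.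

Compound 3 `C=C[C@@](C)(/C=C/c1ccc(-c2ccc(F)cc2)cc1)CCC=C(C)C` is the unmeasured compound. Its change from compound 2 is 4-fluorophenyl in place of (3,4-difluorophenyl)amino on an aromatic carbon. Among the compounds with values here, no measured step bears on this change in a readable way, since the only step available is unreadable. Compound 3 is expected to remain near the limit, with a step that the limit leaves unreadable from compound 2 to compound 3 that is estimated to lie within scatter. The estimate for compound 3 in this assay is 60000 nM, expected to fall between 20000 nM and 200000 nM.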

Compound 3, half-maximal effective concentration: > 43400 nM
Compound 3: only a limit was reported; the forecaster's own chance of this, stated with the estimate: 80%; the middle value lies beyond the limit too.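

Compound 3, like compound 1 and compound 2, gives only a limit in this assay, so no step among these three compounds can be read: the limit of > 43400 nM in this assay, at which 3 of the 3 values shown sit.

The compounds shown leave open how much of each compound the effect requires, and whether 4-fluorophenyl in place of (3,4-difluorophenyl)amino changes that amount at all.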